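Dropping One Chloro Group: What Compound 3 Might Show

A few compounds are considered here, and "the series" means these few. Any claim that something is new, unique, unknown or untested is made for them only; others in the source may bear on it.

Measured compounds:
- compound 1 `ClCc1ccccc1Cn1cnc2c(Cl)ncnc21`: in a functional assay on K562 cells (Homo sapiens) for cytotoxicity, read by sulforhodamine B assay, with a stated time of 48 h (on this read-out higher numbers stand for lower toxicity in this test and lower numbers for higher toxicity in this test), compound 1 gives > 100000 nM, a limit of the test rather than a number
- compound 2 `ClCc1ccc(Cn2cnc3nc(Cl)nc(Cl)c32)cc1`: in this assay compound 2 gives > 100000 nM, again a limit, not a number

Compound 2 therefore stands at the top of what the test can report, with no measurable toxicity, and compound 1 sits at the same place (the limit of > 100000 nM in this assay, at which 2 of the 2 values shown sit). Compound 3 `ClCc1ccc(Cn2cnc3ncnc(Cl)c32)cc1` differs from compound 2 by hydrogen in place of chloro on an aromatic carbon. Going by the values given here, no measured pair shows this change, so its direction is unknown; the expectation is a step of no clear size, with compound 3 most likely again at the limit. For compound 3 in this assay the expected value is 100000 nM, between 30000 nM and 300000 nM, a step of a number no higher from compound 2 to compound 3 (the limit leaves the size open).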

Compound 3, concentration lethal to 50% of the cells: > 100000 nM
Compound 3 gave a limit, no number (the forecaster's own chance of this, stated with the estimate: 85%); the middle value sits exactly at the limit.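

Compound 2 and compound 3 both stop at a limit of the test rather than a number, so no step can be read between them: the limit of > 100000 nM in this assay, at which 3 of the 3 values shown sit. From the compounds shown here alone, whether hydrogen in place of chloro changes toxicity at all stays open.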